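The compounds below may be only part of what the source reports. "The series", "measured", "known", "first", "only" and "open" are said of these compounds alone.

Measured compounds in an assay on isolated protein for inhibition of acid ceramidase (Homo sapiens), read by LC-MS, with a stated time of 1 h; on this read-out lower numbers stand for stronger inhibition and higher numbers for weaker inhibition:
- compound 1 `O=c1[nH]cc(-c2ccccc2)o1`: "not active" (no number reported)
- compound 2 `CCCCCNC(=O)n1cc(-c2ccccc2)oc1=O`: 39 nM
- compound 3 `O=C(NCCCCc1ccccc1)n1cc(-c2ccc(F)cc2)oc1=O`: 185 nM

Compound 1 carries no group on the ring nitrogen of the shared core and gives no number at all in this assay. Compound 2 adds a pentylcarbamoyl group on that nitrogen and gives 39 nM. Compound 3 carries a 4-phenylbutylcarbamoyl group on the nitrogen and a 4-fluorophenyl on the ring carbon; with 185 nM it stands at the higher of the two numbers reported, and the gap to compound 2 lies beyond the usual scatter of the assay.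

Compound 4 `O=C(NCCCCc1ccccc1)n1cc(-c2ccccn2)oc1=O` is the next step from compound 3. The change is pyridin-2-yl in place of 4-fluorophenyl on an aromatic carbon. The chain on the nitrogen is unchanged. For the measured compounds named here, no pair of measured compounds in this set differs only at this position, so the size of the step cannot be read from a neighbour. With nothing pointing either way, a modest loss of potency, or no change beyond the scatter, seems the most defensible expectation, so the step from compound 3 to compound 4 is estimated at a 2.2-fold higher number from compound 3 to compound 4 (0.33 log units; beyond the scatter). Compound 4 is therefore expected to give about 400 nM in this assay, most plausibly between 120 nM and 1500 nM.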

Compound 4, half-maximal inhibitory concentration: 25 nM
Estimate against measurement, compound 4: 16-fold (1.20 log units) above; measured number below the stated range.
By their numbers in this assay, from the lowest: compounds 4 and 2 (each within the scatter of the next); then compound 3.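

In this assay, for the compounds shown here, replacing 4-fluorophenyl with pyridin-2-yl while the 4-phenylbutylcarbamoyl chain stays the same gives a 7.4-fold lower number from compound 3 to compound 4 (0.87 log units; beyond the scatter), the first direct reading of this position, on the aromatic carbon next to the ring oxygen. It shows that the choice of aromatic ring at this place can shift the number beyond the scatter, and that a ring with 1 hetero atom and 1 hydrogen-bond acceptor is tolerated here with a gain in inhibition. No measurement accompanies this step that could explain it, and a single step cannot separate the loss of the fluorine from the arrival of the nitrogen in the ring.

The compounds shown leave open whether the place of that nitrogen matters, as pyridin-3-yl or pyridin-4-yl would test, and whether plain phenyl on the same chain would fall nearer compound 3 or compound 4. They also leave open whether pyridin-2-yl gives a similar step on the pentylcarbamoyl chain of compound 2, and how a ring with a second nitrogen, such as pyrimidin-2-yl, would behave.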